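Methoxy in place of hydrogen: compound 2 to compound 4

A few compounds are considered here, and "the series" means these few. Any claim that something is new, unique, unknown or untested is made for them only; others in the source may bear on it.

Compound 1 `COc1ccc(/C=C/S(=O)(=O)Cc2ccc(OC)cc2)cc1`, compound 2 `COc1ccc(CS(=O)(=O)/C=C/c2ccc(OC)c(OC)c2)cc1` and compound 3 `COc1ccc(CS(=O)(=O)/C=C/c2cc(OC)c(OC)cc2OC)cc1` carry a growing number of methoxy groups on one aromatic ring. In a functional assay on BT-20 cells (Homo sapiens) for antiproliferative activity, read by trypan blue exclusion (on this read-out lower numbers stand for stronger inhibition and higher numbers for weaker inhibition), compound 1 gives > 20000 nM, which is a limit of the assay and not a number. In this assay compound 2 gives > 20000 nM, likewise a limit. In this assay compound 3 gives > 20000 nM, again a limit. Compound 2 thus stands at the limit with the other two, as the limit of > 20000 nM in this assay, at which 3 of the 3 values shown sit, shows. The step that the two limits leave unreadable from compound 1 to compound 2 and the step that the two limits leave unreadable from compound 2 to compound 3 are each methoxy in place of hydrogen on an aromatic carbon, and neither can be read in size or direction; both ends are limits. Compound 4 `COc1ccc(CS(=O)(=O)/C=C/c2ccc(OC)c(OC)c2OC)cc1` differs from compound 2 by methoxy in place of hydrogen on an aromatic carbon. The two measured steps bear directly on this change yet give no size, so in this assay no step beyond the scatter can be foreseen. Compound 4 is expected to give 30000 nM, with a range of 10000 nM to 100000 nM, most probably again reported as a limit. The step expected from this estimate is a step that the limit leaves unreadable from compound 2 to compound 4.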

Compound 4, half-maximal inhibitory concentration: > 20000 nM
Compound 4: a limit, no number; the forecaster's own chance of this, stated with the estimate: 85%; the middle value is on the limit's open side.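

Within the data shown here, compound 2 and compound 4 both sit at a limit of the assay and not at a number, so no step between them can be read: the limit of > 20000 nM in this assay, at which 4 of the 4 values shown sit. The compounds shown leave open whether methoxy in place of hydrogen on an aromatic carbon changes the result in this assay by any readable amount.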